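The compounds below may be only part of what the source reports. "The series", "measured", "known", "first", "only" and "open" are said of these compounds alone.

In a physicochemical assay for solubility, using the shake flask method, in simulated intestinal fluid, measured as kinetic solubility, with a stated time of 20 h, at pH 6.5 (on this read-out higher numbers stand for higher solubility and lower numbers for lower solubility), three compounds sharing one core have been measured, and all three results are limits. Compound 1 `N#Cc1ccc(Nc2cc3[nH]c(-c4cccc(C(F)(F)F)c4)nc3cn2)nc1` gives >= 50000 nM, which is a limit. Compound 2 `FC(F)(F)c1ccc(Nc2cc3[nH]c(-c4cccc(C(F)(F)F)c4)nc3cn2)nc1` gives >= 50000 nM, also a limit. Compound 3 `CN1CCN(c2ccc(Nc3cc4[nH]c(-c5cccc(C(F)(F)F)c5)nc4cn3)nc2)CC1` gives < 5000 nM, again a limit. Compound 2 therefore stands at the limit of >= 50000 nM in this assay, at which 2 of the 3 values shown sit.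

Compound 4 `FC1(F)CCC(c2nc3cnc(Nc4ccc(C(F)(F)F)cn4)cc3[nH]2)C1` keeps the rest of compound 2 but carries 3,3-difluorocyclopentyl in place of 3-(trifluoromethyl)phenyl on an aromatic carbon.

Among the compounds with values here, no measured step changes this group, so the measured steps bear on it only indirectly. Within the data shown here, the first is a step that the two limits leave unreadable from compound 1 to compound 2. The two falls are an at least 10-fold lower number from compound 1 to compound 3 (1.00 log units; beyond the scatter) and an at least 10-fold lower number from compound 2 to compound 3 (1.00 log units; beyond the scatter), and both came with 4-methylpiperazin-1-yl, a group that compound 4 does not carry. Going by these compounds, no step beyond the scatter is therefore expected in this assay, though the size of this change remains untested. The expected step is an at least 1.1-fold lower number from compound 2 to compound 4 (0.04 log units; that floor lies within the scatter). For compound 4, the estimated value is 45000 nM, with an expected range from 15000 nM to 100000 nM.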

Compound 4, solubility: 163000 nM
Estimate against measurement, compound 4: 3.6-fold (0.56 log units) below; the whole stated range lies below it.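

Compound 2 is known only as a limit, >= 50000 nM, so the step from it to compound 4 cannot be read in this assay. The compounds shown leave open how far 3,3-difluorocyclopentyl and 3-(trifluoromethyl)phenyl actually differ in this assay, or whether they differ at all.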